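The source may report more compounds than this note shows. Statements on the series, on what has been measured and on what is new or still open speak of the compounds shown alone.

Compound 1 `CCCNC(=O)c1cc(-n2cc(CCC(C)C)nn2)ccc1O` and compound 2 `CCCCCCc1cn(-c2ccc(O)c(C(=O)NCCC)c2)nn1` share one core. In a functional assay on RAW264.7 cells (Mus musculus) for inhibition, read by Griess assay, with a stated time of 20 h (a lower number here means a stronger inhibitor, a higher number a weaker inhibitor), compound 1 gives only a limit, > 20000 nM. In this assay compound 2 gives 19700 nM. The change between them, (butyl in place of isopropyl on a saturated chain carbon, two bonds along the chain from an aromatic carbon), made an at least 1.0-fold lower number from compound 1 to compound 2 (0.00 log units; that floor lies within the scatter). Compound 3 `CC(C)CCc1cn(-c2ccc(C(=O)N3CCCCC3)c(O)c2)nn1` carries another core; the difference between the two cores is not broken down here. In this assay compound 3 gives only a limit, > 20000 nM. Compound 4 `CCCCCCc1cn(-c2ccc(C(=O)N3CCCCC3)c(O)c2)nn1` has not yet been measured in this assay; it differs from compound 3 by the same change, (butyl in place of isopropyl on a saturated chain carbon, two bonds along the chain from an aromatic carbon). Since the earlier step stayed within the scatter and the results so far are dominated by the limit of > 20000 nM in this assay, at which 2 of the 3 values shown sit, the step from compound 3 to compound 4 is expected to be a number no higher from compound 3 to compound 4 (the limit leaves the size open). Compound 4 is therefore estimated at 20000 nM, between 8000 nM and 50000 nM, most likely reported as a limit again.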

Compound 4, half-maximal inhibitory concentration: > 20000 nM
Compound 4 gave a limit, no number; the forecaster's own chance of this, stated with the estimate: 70%; the middle value sits exactly at the limit.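

In this assay, going by these compounds alone, compound 3 and compound 4 both give only a limit, so no step between them can be read. The compounds shown leave open whether butyl in place of isopropyl changes anything on the core of compound 3, since most results rest at one ceiling: the limit of > 20000 nM in this assay, at which 3 of the 4 values shown sit.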